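Carbamoyl in place of fluoro: expectation for compound 4

The source may report more compounds than this note shows. Statements on the series, on what has been measured and on what is new or still open speak of the compounds shown alone.

Measured so far in a functional assay for agonist activity at Free fatty acid receptor 1 (Homo sapiens); a lower number here means that less compound is needed, a higher number that more compound is needed for the effect:
Compound 1 `O=C(O)CCc1ccc(NCc2cccc(F)c2)cc1` gives 5010 nM.
Compound 2 `CN(C)Cc1ccc(CNc2ccc(CCC(=O)O)cc2)cc1` gives only a limit, < 31700 nM.
Compound 3 `O=C(O)CCc1ccc(NCc2ccc(O)cc2)cc1` gives only a limit, < 31700 nM.

Among the measured compounds shown here, compound 1 stands alone as the only number in the set; the other two values are limits, as the limit of < 31700 nM in this assay, at which 2 of the 3 values shown sit, states. For the measured compounds named here, the single one-place step, from compound 2 to compound 3, is a step that the two limits leave unreadable from compound 2 to compound 3, since both ends sit at the limit, and it concerns a hydroxy in place of a (dimethylamino)methyl, not the change at hand.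

Compound 4 `NC(=O)c1cccc(CNc2ccc(CCC(=O)O)cc2)c1` differs from compound 1 by carbamoyl in place of fluoro on an aromatic carbon. Going by the values given here, no measured step bears on this change directly; the only comparison, from compound 2 to compound 3, is unreadable. Among the compounds with values here, what the set does show is that compound 1, with fluoro, is the one compound with a number, while compound 2 and compound 3 each stop at a limit. On that basis compound 4 is expected to lie somewhat weaker than compound 1, a step of a 2.4-fold higher number from compound 1 to compound 4 (0.38 log units; beyond the scatter), with a fair chance that only a limit is returned. The estimate for compound 4 in this assay is 12000 nM, within 3500 nM to 40000 nM.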

Compound 4, half-maximal effective concentration: < 31700 nM
Compound 4: no number, only a limit; the forecaster's own chance of this, stated with the estimate: 35%; the middle value does not contradict the limit.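

In this assay compound 4 gives only a limit (< 31700 nM). No step between compound 1 and compound 4 can be read: the limit of < 31700 nM in this assay, at which 3 of the 4 values shown sit.

On these data alone, how far carbamoyl in place of fluoro on an aromatic carbon shifts the value of compound 1 (5010 nM) stays open, including the direction of any shift.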